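The source may report more compounds than this note shows. Statements on the series, on what has been measured and on what is new or still open speak of the compounds shown alone.

Compound 1, `CCN(CC)c1ccc(NC(=O)c2c(-c3c(Cl)cccc3Cl)noc2CCC2OCCCO2)c(C)c1`: 10 nM
Compound 2, `CCc1cc(N(CC)CC)ccc1NC(=O)c1c(-c2c(Cl)cccc2Cl)noc1C`: 41 nM

In a functional assay on CHO K cells for inhibition of growth hormone secretagogue receptor type 1 (Homo sapiens), read by FLIPR (a lower number here means a stronger inhibitor, a higher number a weaker inhibitor), compound 2 gives the higher of the two numbers; compound 1 gives a lower number, and that gap lies beyond the usual scatter. Compound 3, `CCN(CC)c1ccc(NC(=O)c2c(-c3c(Cl)cccc3Cl)noc2C)c(C)c1`, differs from compound 2 by hydrogen in place of methyl on a saturated chain carbon bound to an aromatic carbon. Within the data shown here, no pair of measured compounds shows this change, so its size is not known from these data. Such a small trimming of a chain is expected to move the number only modestly, if at all, and the step of a 1.6-fold lower number from compound 2 to compound 3 (0.21 log units; within the scatter) is expected to stay close to the scatter, leaning toward a lower number. Compound 3 is therefore expected to give about 25 nM, within a range from 8 nM to 70 nM.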

Compound 3, half-maximal inhibitory concentration: 39 nM
Beside the measured number, compound 3's estimate is 1.6-fold (0.19 log units) below it, and the stated range covers the measured number.
By their numbers in this assay, from the lowest: compound 1; then compounds 3 and 2 (each within the scatter of the next).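

Trimming ethyl to methyl leaves the number in this assay unchanged within the scatter (a 1.1-fold lower number from compound 2 to compound 3 (0.02 log units; within the scatter)), so at this place the two chains cannot be told apart. The larger change does register: replacing the group of 7 heavy atoms, with its six-membered non-aromatic ring, by a hydrogen atom gives a step beyond the scatter (a 3.9-fold higher number from compound 1 to compound 3 (0.59 log units; beyond the scatter)). No supporting measurement accounts for either result. Still open, as far as these compounds go, is whether a longer chain such as propyl, or an amine, would behave like ethyl at this place. Which part of the larger group carries the difference also remains unknown.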